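The source may report more compounds than this note shows. Statements on the series, on what has been measured and on what is new or still open speak of the compounds shown alone.

Measured so far:
- compound 1 `CC(C)Oc1cc(C(=O)Nc2cc(-c3ccccn3)n[nH]2)cc(C(=O)N2CCCC2)c1`: > 40300 nM
- compound 2 `COc1ccc(C(=O)Nc2[nH]nc(-c3ccccn3)c2C2CC2)cc1`: > 64000 nM
- compound 3 `O=C(Nc1cc(-c2ccccn2)n[nH]1)N1CCC(c2cccc(F)c2)CC1`: > 45000 nM

All three entries are limits and not numbers, and no measured step links any two of these compounds. In an ADME assay on cells (Peritoneal macrophage cell, Mus musculus) for cytotoxicity, read by fluorescence and resazurin assay, with a stated time of 3 days (a higher number here means that more compound is tolerated, a lower number that less compound is tolerated), compound 3 gives > 45000 nM, which is a limit.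

Compound 4 `O=C(Nc1cc(-c2ccccn2)n[nH]1)N1CCC(c2ccc(F)cc2)CC1` has 4-fluorophenyl in place of 3-fluorophenyl on a saturated ring carbon. The two compounds have the same atoms, joined differently. Within the data shown here, with no measured step to draw on, no change beyond the usual scatter is expected in this assay. The expected step of a number no higher from compound 3 to compound 4 (the limit leaves the size open) is only an estimate, since compound 3 has no numerical value to start from. Another limit is the likeliest report for compound 4. For compound 4 the estimated value is 45000 nM, with an expected range of 20000 nM to 64000 nM.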

Compound 4, half-maximal cytotoxic concentration: > 64000 nM
Compound 4 gave a limit, no number (the forecaster's own chance of this, stated with the estimate: 85%); middle value at least 1.4-fold (0.15 log units) away from the limit.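

In this assay compound 3 gives > 45000 nM, a limit. Among these compounds, compound 4 gives > 64000 nM, also a limit, so no step between the two can be read. With only limits shown for all four compounds, the half-maximal cytotoxic concentration of each remains open, as does any difference between 3-fluorophenyl and 4-fluorophenyl.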